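The source may report more compounds than this note shows. Statements on the series, on what has been measured and on what is new or still open speak of the compounds shown alone.

Compound 1 `CC(O)(C[S+]([O-])c1ccc(F)cc1F)C(=O)Nc1ccc([N+](=O)[O-])cc1C(F)(F)F` is one of two closely related compounds examined here, and both rest on the same shared core. In a functional assay on DU-145 cells (Homo sapiens) for antiproliferative activity (on this read-out higher numbers stand for weaker inhibition and lower numbers for stronger inhibition), compound 1 gives only a limit of the assay, > 100000 nM, and not a measured number. Its companion, compound 2 `CC(O)(C[S+]([O-])c1ccc(F)c(F)c1)C(=O)Nc1ccc([N+](=O)[O-])cc1C(F)(F)F`, stands in the same place. In this assay compound 2 likewise gives only a limit, > 100000 nM; > 100000 nM (2 entries). Compound 1 therefore sits at the limit of > 100000 nM in this assay, at which 1 of the 2 values shown sits, so there is no number that would let it be ranked against compound 2 or anything else; the two show only that neither reached a measurable inhibition.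

Compound 3 `CC(O)(C[S+]([O-])c1ccc(OC(F)(F)F)cc1)C(=O)Nc1ccc([N+](=O)[O-])cc1C(F)(F)F` has not yet been measured. It differs from compound 1 in a single place: 4-(trifluoromethoxy)phenyl in place of 2,4-difluorophenyl on a sulfur. Within the data shown here, no step between measured compounds is known, and the two values that exist are both limits, so there is no measured basis for expecting a step in either direction. The step from compound 1 is expected to be none beyond the scatter, a step that the limit leaves unreadable from compound 1 to compound 3. Compound 3 is estimated to give 150000 nM, with a likely range from 50000 nM to 500000 nM, and most probably again only a limit.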

Compound 3, half-maximal inhibitory concentration: > 100000 nM
Compound 3: no number, only a limit; the forecaster's own chance of this, stated with the estimate: 80%; the middle value is on the limit's open side.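

Among these compounds, compound 3, like compound 1, gives only a limit in this assay and not a measured number, so no step from compound 1 to compound 3 can be read. The compounds shown leave open whether 4-(trifluoromethoxy)phenyl in place of 2,4-difluorophenyl on a sulfur changes inhibition at all, and what would give this series a measurable value.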